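Isoquinoline to indazole swap on the urea of compound 2

The compounds below may be only part of what the source reports. "The series", "measured", "known", "first", "only" and "open" are said of these compounds alone.

Working notes on the series. In a functional assay for antagonist activity at transient receptor potential cation channel subfamily V member 1 (Homo sapiens), read by calcium flux (a lower number here means a stronger inhibitor, a higher number a weaker inhibitor), compound 1 `O=C(NCc1ccc(N2CCCCCC2)cc1)Nc1cccc2cnccc12` gives 3.3 nM. Compound 2 `O=C(NCc1ccc(N2CCCCCC2)c(C(F)(F)F)c1)Nc1cccc2cnccc12` carries trifluoromethyl in place of hydrogen on an aromatic carbon; in this assay compound 2 gives 4.6 nM, a step of a 1.4-fold higher number from compound 1 to compound 2 (0.14 log units; within the scatter). Compound 3 `O=C(NCc1ccc(N2CCCCCC2)c(F)c1)Nc1cccc2cnccc12` carries fluoro in place of hydrogen on an aromatic carbon; in this assay compound 3 gives 2.8 nM, which is a 1.2-fold lower number from compound 1 to compound 3 (0.07 log units; within the scatter) and a 1.6-fold lower number from compound 2 to compound 3 (0.22 log units; within the scatter). Compound 2 thus sits with the others inside one band: its steps to compound 1 and to compound 3 are both within the scatter, so the three numbers do not separate.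

Compound 4 `O=C(NCc1ccc(N2CCCCCC2)c(C(F)(F)F)c1)Nc1cccc2[nH]ncc12` differs from compound 2 by 1H-indazol-4-yl in place of isoquinolin-5-yl on an amide-type nitrogen. None of the three measured steps touches the aryl group on the amide-type nitrogen; all of them concern a substituent on an aromatic carbon of the other ring, and all are within the scatter. Among the compounds with values here, no measured step therefore bears on this change, and the expectation for compound 4 rests only on the tight band of compound 1, compound 2 and compound 3.

Compound 4 is estimated at 8 nM, with a range of 2 nM to 30 nM. The step of a 1.7-fold higher number from compound 2 to compound 4 (0.24 log units; within the scatter) is expected to be small against a wide uncertainty.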

Compound 4, half-maximal inhibitory concentration: 29.5 nM
Estimate against measurement, compound 4: 3.7-fold (0.57 log units) below; the range from low to high includes it.
By their numbers in this assay, from the lowest: compounds 3, 1 and 2 (each within the scatter of the next); then compound 4.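

In this assay the aryl group on the amide-type nitrogen is the only place among those shown where a single change moves the number beyond the scatter: 1H-indazol-4-yl in place of isoquinolin-5-yl gives a 6.4-fold higher number from compound 2 to compound 4 (0.81 log units; beyond the scatter) and so separates compound 4 from the band, whereas the substituent changes on the other ring, such as a 1.4-fold higher number from compound 1 to compound 2 (0.14 log units; within the scatter) and a 1.2-fold lower number from compound 1 to compound 3 (0.07 log units; within the scatter), stay within the scatter. Within the data shown here, this position therefore responds to change in a way the earlier steps could not reveal, though the step is modest in size. The swap alters several things at once, with a five-membered aromatic ring with 2 hetero atoms entering, and 1 hydrogen-bond donor against 0 hydrogen-bond donors, and nothing measured here ties the step to any one of these differences.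

From the compounds shown here alone, whether the same swap gives a step of similar size on compound 1 or compound 3 remains open. Also open, going by these compounds, is how 1-methyl-1H-indazol-4-yl, or a plain naphthalen-1-yl, would stand at this position against compound 2 and compound 4.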